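Phenyl added to the ester chain of compound 1

This account rests on a few compounds, and the source may have more. Where it says the series, first, only, none or still open, it means among the compounds named here.

Compound 1 `C/C=C1/[C@H](O[C@@H]2O[C@H](CO)[C@@H](O)[C@H](O)[C@H]2O)OC=C(C(=O)OC)[C@H]1CC(=O)OCC`: in a functional assay on SK-BR-3 cells (Homo sapiens) for antiproliferative activity, read by MTT assay, with a stated time of 72 h (a higher number here means a weaker inhibitor, a lower number a stronger inhibitor), compound 1 gives > 15000 nM, a limit of the assay.
Compound 2 `C=CCOC(=O)C[C@@H]1C(C(=O)OC)=CO[C@@H](O[C@@H]2O[C@H](COC(C)=O)[C@@H](OC(C)=O)[C@H](OC(C)=O)[C@H]2OC(C)=O)/C1=C/C`: in this assay compound 2 gives > 20000 nM, also a limit.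

Compound 1 stands at the limit of > 15000 nM in this assay, at which 1 of the 2 values shown sits, so only a limit is known for it, and compound 2 likewise sits at the limit of > 20000 nM in this assay, at which 1 of the 2 values shown sits. Among the measured compounds shown here, no measured pair differs in one place, so nothing here shows how a single change moves the read-out. Compound 3 `C/C=C1/[C@H](O[C@@H]2O[C@H](CO)[C@@H](O)[C@H](O)[C@H]2O)OC=C(C(=O)OC)[C@H]1CC(=O)OCCc1ccccc1` differs from compound 1 by phenyl in place of hydrogen on a saturated chain carbon, two bonds along the chain from an oxygen next to a carbonyl group. Compound 3 is expected to move by a number no higher from compound 1 to compound 3 (the limit leaves the size open), no more than the scatter and with no clear direction. Compound 3 is therefore estimated at 15000 nM, between 5000 nM and 50000 nM.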

Compound 3, half-maximal inhibitory concentration: 11000 nM
For compound 3 the middle estimate is 1.4-fold (0.13 log units) above the measured one; the measured number falls inside the stated range.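

In this assay, among the compounds shown here, compound 3 gives 11000 nM, the only value shown that is a number and not a limit, so phenyl at this place on the ester chain brings the read-out to a figure that can be stated. The change amounts to an at least 1.3-fold lower number from compound 1 to compound 3 (0.13 log units; that floor lies within the scatter). Its true size stays open because compound 1 is known only as a limit: the limit of > 15000 nM in this assay, at which 1 of the 3 values shown sits.

The compounds shown leave open whether a longer chain carrying the phenyl, or an amine on that phenyl, would move the number any further.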